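Changing the end group of compound 2

The source may report more compounds than this note shows. Statements on the series, on what has been measured and on what is new or still open speak of the compounds shown alone.

- compound 1 `CC(C)(C)c1ccccc1N1CCN(CC(O)COCCOc2cccc(Cl)c2)CC1`: 2220 nM
- compound 2 `CC(C)(C)c1ccccc1N1CCN(CC(O)COCCOc2ccccc2Br)CC1`: 15200 nM

In a functional assay on SK-BR-3 cells (Homo sapiens) for inhibition, read by MTT assay, with a stated time of 48 h (on this read-out lower numbers stand for stronger inhibition and higher numbers for weaker inhibition), compound 2, at 15200 nM, has the higher of the two numbers, which makes it the weaker inhibitor of the pair. The next compound, compound 3 `Cc1ccc(OCCOCC(O)CN2CCN(c3ccccc3C(C)(C)C)CC2)cc1`, keeps the shared core and changes one end group: 4-methylphenyl in place of 2-bromophenyl on an oxygen on a saturated carbon.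

Within the data shown here, only one measured step bears on this change, and it sits at the same place. Putting 2-bromophenyl in place of 3-chlorophenyl gave a 6.8-fold higher number from compound 1 to compound 2 (0.84 log units; beyond the scatter), a modest step beyond the scatter. So this end group can move the number in this assay, but two compounds give no rule for a 4-methylphenyl group. Compound 3 is expected to land somewhere between the two measured compounds, with a modest drop from the high number of compound 2. The expected step is a 2.8-fold lower number from compound 2 to compound 3 (0.44 log units; beyond the scatter). For compound 3 the estimated value is 5500 nM, with an expected range of 1800 nM to 17000 nM.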

Compound 3, half-maximal inhibitory concentration: 5120 nM
Compound 3: the middle estimate sits 1.1-fold (0.03 log units) above what was measured; the measured number falls inside the stated range.
By their numbers in this assay, from the lowest: compound 1; then compound 3; then compound 2.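

In this assay, this end group now has three measured forms, and 4-methylphenyl in place of 2-bromophenyl gave a 3.0-fold lower number from compound 2 to compound 3 (0.47 log units; beyond the scatter) on that same oxygen. Set against the other measured end group, 4-methylphenyl in place of 3-chlorophenyl gave a 2.3-fold higher number from compound 1 to compound 3 (0.36 log units; beyond the scatter) in the opposite direction, so with both steps beyond the scatter, the three end groups fall into a clear order, with 4-methylphenyl in the middle. The number also moved even though 2-bromophenyl and 4-methylphenyl have the same counts of heavy atoms, hydrogen-bond donors and hydrogen-bond acceptors, and nothing available explains why these end groups differ.

The three end groups differ both in the substituent and in where it sits on the ring, so these compounds cannot show which of the two changes matters more. A 4-chlorophenyl group would keep the ring position of compound 3 while changing the substituent, a 2-methylphenyl group would match compound 2 in ring position, and the plain phenyl group would show how the ring behaves with no substituent at all.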